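Ethoxy to isopropoxy: working notes on the series

The compounds below may be only part of what the source reports. "The series", "measured", "known", "first", "only" and "open" are said of these compounds alone.

Measured in an ADME assay on BJ cells (Homo sapiens) for cytotoxicity, read by luminescence, with a stated time of 72 h; a lower number here means that less compound is needed, a higher number that more compound is needed for the effect:
- compound 1 `CCOC(=O)c1c(-c2cccc(OC)c2)[nH]c2cc(OC)ccc2c1=O`: > 21500 nM (a limit)
- compound 2 `CCOC(=O)c1c(-c2cccc(OCC)c2)[nH]c2cc(OC)ccc2c1=O`: > 21500 nM (a limit)

Compound 2 gives only a limit, > 21500 nM, and no number. The other measured compound stands no differently: the limit of > 21500 nM in this assay, at which 2 of the 2 values shown sit.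

The next compound, compound 3 `CCOC(=O)c1c(-c2cccc(OC(C)C)c2)[nH]c2cc(OC)ccc2c1=O`, is not yet measured. It changes ethoxy to isopropoxy, with this difference from compound 2: methyl in place of hydrogen on a saturated chain carbon bound to an oxygen on an aromatic ring and a saturated chain carbon.

Among the measured compounds shown here, one measured step bears on this change. It also puts methyl in place of hydrogen on a saturated chain carbon bound to an oxygen on an aromatic ring, and it reads: a step that the two limits leave unreadable from compound 1 to compound 2. That step gives no size to carry over, so the expectation rests on a weak basis. No step beyond the scatter is expected in this assay, and no direction can be given. Another report as a limit is the likeliest outcome.

For compound 3 the estimated value is 30000 nM, with an expected range of 15000 nM to 60000 nM. The expected step is a step that the limit leaves unreadable from compound 2 to compound 3.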

Compound 3, half-maximal effective concentration: > 21500 nM
Compound 3 ended at the assay's limit; the forecaster's own chance of this, stated with the estimate: 85%; the middle value lies beyond the limit too.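

Compound 3 gives > 21500 nM, a limit and not a number. No step from compound 1 or compound 2 to compound 3 can be read: the limit of > 21500 nM in this assay, at which 3 of the 3 values shown sit.

The compounds shown leave open whether methyl, ethyl and isopropyl on the oxygen differ at all in this assay, and at what concentration any of the three compounds reaches the half-maximal effect.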